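Removing the carboxy from the side chain of compound 1

The source may hold more compounds than are shown below. What is called first, only, known or untested is meant among the compounds shown, and "the series" means these compounds.

Compound 1 `COc1ccc(NC(=O)C(=O)c2cn(C(C)(C)COCC(=O)O)c3ccccc23)cn1` is measured in a physicochemical assay for solubility, in phosphate buffer, at pH 7.4 (on this read-out lower numbers stand for lower solubility and higher numbers for higher solubility), only as a limit, <= 200000 nM, so its place among the numbers cannot be fixed (the limit of <= 200000 nM in this assay, at which 1 of the 3 values shown sits). Compound 2 `COc1ccc(NC(=O)C(=O)c2cn(C(C)C)c3ccccc23)cn1` gives 20000 nM in this assay. Compound 3 `COCC(C)n1cc(C(=O)C(=O)Nc2ccc(OC)nc2)c2ccccc21` gives 40000 nM in this assay. The steps a step that the limit leaves unreadable from compound 1 to compound 2 and a step that the limit leaves unreadable from compound 1 to compound 3 therefore carry no readable size, while a 2.0-fold higher number from compound 2 to compound 3 (0.30 log units; within the scatter) stays within the scatter. Compound 4 `COCC(C)(C)n1cc(C(=O)C(=O)Nc2ccc(OC)nc2)c2ccccc21` differs from compound 1 by hydrogen in place of carboxy on a saturated chain carbon bound to an oxygen on a saturated carbon. Within the data shown here, no measured step reads the size of this change, so the expectation rests on compound 3, whose side chain is nearest. Compound 4 is expected at 30000 nM, within 8000 nM to 100000 nM, a step that the limit leaves unreadable from compound 1 to compound 4 that the limit on compound 1 leaves unreadable in direction.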

Compound 4, solubility: 10000 nM
Compound 4: middle estimate off by 3.0-fold (0.48 log units), on the high side; the range from low to high includes it.
By their numbers in this assay, from the lowest: compounds 4, 2 and 3 (each within the scatter of the next, the first and the last beyond it).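

In this assay, among these compounds, methyl in place of hydrogen on a saturated chain carbon bound to an aromatic nitrogen and two saturated chain carbons gives a 4.0-fold lower number from compound 3 to compound 4 (0.60 log units; beyond the scatter), the only readable step beyond the scatter. Methoxymethyl in place of hydrogen at that same carbon gives a 2.0-fold lower number from compound 2 to compound 4 (0.30 log units; within the scatter). The steps from compound 1 cannot be read, so hydrogen in place of carboxy has no size here: the limit of <= 200000 nM in this assay, at which 1 of the 4 values shown sits.

Still open, going by these compounds, is whether an amine in place of the methoxy of compound 4 would give a readable value. The same holds for a carboxylic acid on a shorter chain.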